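The source may hold more compounds than are shown below. What is called first, only, known or untested is meant among the compounds shown, and "the series" means these compounds.

Compound 1 `CC(C)(C)OC(=O)NCCCCCN1C(Nc2ccc(-c3ccccc3)cc2)=Nc2ccccc2C1CC(=O)NCc1ccccc1`: 170 nM
Compound 2 `COC(=O)CC1c2ccccc2N=C(NCCCCCNC(=O)OC(C)(C)C)N1c1ccc(-c2ccccc2)cc1`: 680 nM
Compound 3 `Cc1ccc(S(=O)(=O)Nc2ccc(CNC(=O)CC3c4ccccc4N=C(N4CCCCC4)N3c3ccccc3)cc2)cc1`: 170 nM

In an assay on HEK293 cells for inhibition of Voltage-dependent T-type calcium channel subunit alpha-1G (Homo sapiens) (a higher number here means a weaker inhibitor, a lower number a stronger inhibitor), compound 1 gives 170 nM. It stands level with compound 3, which gives 170 nM, the two lying within the scatter of each other; together they hold the lowest numbers of the three. Compound 2 gives 680 nM, a higher number than compound 1 and a gap beyond the scatter.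

Compound 4 `NCCCCCN1C(Nc2ccc(-c3ccccc3)cc2)=Nc2ccccc2C1CC(=O)NCc1ccccc1` differs from compound 1 in one place: hydrogen in place of tert-butoxycarbonyl on an amine nitrogen. Within the data shown here, no measured pair shows this same change, so the expectation rests on the change alone. Compound 4 is estimated at 250 nM, with a range from 60 nM to 1000 nM. The expected step of a 1.5-fold higher number from compound 1 to compound 4 (0.17 log units; within the scatter) is small, towards a somewhat higher number, and may not go beyond the scatter.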

Compound 4, half-maximal inhibitory concentration: 140 nM
For compound 4 the middle estimate is 1.8-fold (0.25 log units) above the measured one, within the range that was stated.
By their numbers in this assay, from the lowest: compounds 4, 1 and 3 (each within the scatter of the next); then compound 2.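

In this assay, hydrogen in place of tert-butoxycarbonyl on an amine nitrogen is a step of a 1.2-fold lower number from compound 1 to compound 4 (0.08 log units; within the scatter), so the whole group can go from this position with no difference beyond the scatter. The earlier compounds shown here with this chain all carried tert-butoxycarbonyl, and only compound 4 shows the free amino end. Nothing measured here bears on the reason for this result. The compounds shown leave open whether an acetyl group on that nitrogen, or a shorter or longer chain carrying the amine, would stay within the scatter of compound 4.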